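Ethynyl to Fluoro: Expected Effect on Microsomal Clearance

The source may hold more compounds than are shown below. What is called first, only, known or untested is meant among the compounds shown, and "the series" means these compounds.

Of the compounds shown here, three have been measured in an ADME assay on microsomes from liver (Canis lupus familiaris) for metabolic stability, read by LC-MS, using NADPH, with a stated time of 10 min, tested at 0.1 uM; on this read-out lower numbers stand for slow clearance and higher numbers for fast clearance. Compound 1 `COc1ccccc1N1C(=O)CSC1c1cc(F)cc(C(=O)NCCCCc2ccccc2)c1` gives 2170 mL.min-1.g-1. In this assay compound 2 `C#Cc1cc(C(=O)NCCCCc2ccccc2)cc(C2SCC(=O)N2c2ccccc2OC)c1` gives 1750 mL.min-1.g-1. In this assay compound 3 `C#Cc1cccc(N2C(=O)CSC2c2cccc(C(=O)NCCCCc3ccccc3)c2)c1` gives 973 mL.min-1.g-1. The change fluoro in place of ethynyl on an aromatic carbon produced a 1.2-fold higher number from compound 2 to compound 1 (0.09 log units; within the scatter). Compound 4 `O=C(NCCCCc1ccccc1)c1cccc(C2SCC(=O)N2c2cccc(F)c2)c1` has not yet been measured; it arises from compound 3 by fluoro in place of ethynyl on an aromatic carbon. The difference between the cores of compound 3 and compound 2 is not broken down here. The surroundings of the change differ slightly: in compound 1 the fluoro sits meta to two large groups, whereas in compound 4 it sits meta to a large group, so the two are the same kind of change rather than the same change. Because the earlier step of a 1.2-fold higher number from compound 2 to compound 1 (0.09 log units; within the scatter) was small, compound 4 is expected to show a 1.2-fold higher number from compound 3 to compound 4 (0.07 log units; within the scatter). Compound 4 is estimated at 1150 mL.min-1.g-1, with a likely range from 600 mL.min-1.g-1 to 2300 mL.min-1.g-1.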

Compound 4, intrinsic clearance in microsomes in the Canis lupus familiaris assay: 837 mL.min-1.g-1
Compound 4: the middle estimate sits 1.4-fold (0.14 log units) above what was measured; low and high end bracket the measured number.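

In the Canis lupus familiaris assay compound 4 gives 837 mL.min-1.g-1, and putting fluoro in place of ethynyl gave a 1.2-fold lower number from compound 3 to compound 4 (0.07 log units; within the scatter), so the step stayed small on this second core as well. Set beside the earlier step, the two results cannot be told apart: the same change on two cores in the Canis lupus familiaris assay, a 1.2-fold higher number (0.09 log units; within the scatter) from compound 2 to compound 1 and a 1.2-fold lower number (0.07 log units; within the scatter) from compound 3 to compound 4, 1.4-fold (0.16 log units) apart, within the scatter of two such steps. This shows that in these two pairs the change made no difference larger than repeat measurements would, but two pairs are few, and they do not show that the same would hold on other cores. In a physicochemical assay for solubility, read by turbidimetry, measured as kinetic solubility, at pH 7.4 (on this read-out higher numbers stand for higher solubility and lower numbers for lower solubility), compound 3 gives 10000 nM and compound 4 gives 10000 nM.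

The compounds shown leave open whether another group in this place, such as a nitrile or an amine, would move the number beyond the scatter. They also leave open whether the swap would stay this small with a shorter chain on the amide.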